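The compounds below may be only part of what the source reports. "The series", "measured", "known", "first", "only" and "open" are said of these compounds alone.

Compound 2 `COc1ccc(-c2cc3ccccc3nc2/C=C/C(=O)c2ccc(OC)cc2OC)cc1` is measured in a functional assay on H184B5F5/M10 cells (Homo sapiens) for antiproliferative activity, read by XTT assay, with a stated time of 72 h (on this read-out lower numbers stand for stronger inhibition and higher numbers for weaker inhibition), at 6110 nM. Among the two compounds measured so far it has the higher of the two numbers, but its nearest neighbour, compound 1 `COc1ccc(-c2cc3ccccc3nc2/C=C/C(=O)c2ccc(O)cc2)cc1`, with 5690 nM, is so close that the step of a 1.1-fold higher number from compound 1 to compound 2 (0.03 log units; within the scatter) does not separate them. Compound 3 `COc1ccc(-c2cc3ccccc3nc2/C=C/C(=O)c2ccc(OC)c(OC)c2)cc1` has not yet been measured; it differs from compound 2 by 3,4-dimethoxyphenyl in place of 2,4-dimethoxyphenyl on a carbonyl carbon. Among the compounds with values here, the only step measured so far, a 1.1-fold higher number from compound 1 to compound 2 (0.03 log units; within the scatter), also changed the aromatic group on that same carbonyl carbon and produced no shift beyond the scatter, so a change of pattern within a dimethoxyphenyl group is expected to leave the number about where compound 2 stands. The expected step of a 1.0-fold lower number from compound 2 to compound 3 (0.01 log units; within the scatter) is therefore estimated as nothing beyond the scatter. For compound 3 the estimate is 6000 nM, between 3000 nM and 12000 nM.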

Compound 3, half-maximal inhibitory concentration: 7240 nM
Beside the measured number, compound 3's estimate is 1.2-fold (0.08 log units) below it, within the range that was stated.
By their numbers in this assay, from the lowest: compounds 1, 2 and 3 (each within the scatter of the next).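

In this assay, putting 3,4-dimethoxyphenyl in place of 2,4-dimethoxyphenyl on the carbonyl carbon gives a 1.2-fold higher number from compound 2 to compound 3 (0.07 log units; within the scatter) and shows that rearranging the same atoms within this group, not only exchanging one group for another, leaves the result inside the scatter. Putting 3,4-dimethoxyphenyl in place of 4-hydroxyphenyl gives a 1.3-fold higher number from compound 1 to compound 3 (0.10 log units; within the scatter), so this assay separates none of the three groups tried at this position. Nothing measured here speaks to why these groups are so alike.

Still open, on these data alone, is whether a group of another kind on the carbonyl carbon, such as an aminophenyl or a carboxyphenyl, would move the number beyond the scatter. Also open, as far as these compounds go, is whether a single methoxy group would do the same as two.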